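The source may hold more compounds than are shown below. What is called first, only, known or untested is meant among the compounds shown, and "the series" means these compounds.

Among the compounds with values here, in a functional assay on K562 cells (Homo sapiens) for inhibition, read by sulforhodamine B assay, with a stated time of 48 h (on this read-out higher numbers stand for weaker inhibition of growth and lower numbers for stronger inhibition of growth), compound 3 `CC(C)(C)NCc1c(C(=O)O)nn(-c2ccc(Cl)cc2)c1-c1ccc(Br)cc1` gives 297000 nM, the only true number among the three compounds measured so far. Compound 2 `CC(C)(C)NCc1c(C(=O)O)nn(-c2ccc(Cl)cc2)c1-c1ccc(F)cc1` stands at a limit, > 623000 nM. Compound 1 `Cc1ccc(-c2c(CNC(C)(C)C)c(C(=O)O)nn2-c2ccccc2)cc1`, which carries a 4-methylphenyl group, also stands at a limit, > 688000 nM.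

The next compound, compound 4 `Cc1ccc(-c2c(CNC(C)(C)C)c(C(=O)O)nn2-c2ccc(Cl)cc2)cc1`, differs from compound 3 in one group: methyl in place of bromo on an aromatic carbon, para to a large group (methyl in place of bromo on an aromatic carbon). Within the data shown here, one measured step bears on this change. Bromo in place of fluoro gave an at least 2.0-fold lower number from compound 2 to compound 3 (0.32 log units; beyond the scatter), a modest step beyond the scatter, whose full size remains open since it starts from a limit. Resting on that step, and on the limit reached by compound 1 with its 4-methylphenyl group, a modest rise in this assay is expected, towards weaker inhibition of growth. The expected change is a 2.0-fold higher number from compound 3 to compound 4 (0.31 log units; beyond the scatter). For compound 4 the estimated value is 600000 nM, with an expected range from 300000 nM to 1000000 nM.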

Compound 4, concentration for 50% growth inhibition: > 629000 nM
Compound 4 was reported as a limit; the forecaster's own chance of this, stated with the estimate: 60%; at least 1.0-fold (0.02 log units) between middle value and limit.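

In this assay, within the data shown here, the change from 4-bromophenyl to 4-methylphenyl is the first step at this position to leave from a true number, and it gives an at least 2.1-fold higher number from compound 3 to compound 4 (0.32 log units; beyond the scatter). Compound 4 is reported only as a limit: the limit of > 629000 nM in this assay, at which 1 of the 4 values shown sits. The steps to compound 4 from compound 2 and from compound 1 cannot be read, so among fluoro, bromo and methyl at this position, only bromo, in compound 3, carries a true number.

Going by these compounds, how far the number rises with methyl stays open, as the step has only a minimum size. The compounds shown also leave open whether chloro, methoxy or trifluoromethyl at this position would give a true number, and whether an amide in place of the carboxylic acid would change the number of compound 3.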